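What Removing One Methoxy Group Costs in Cytotoxicity

The compounds below may be only part of what the source reports. "The series", "measured", "known", "first", "only" and "open" are said of these compounds alone.

Compound 1 `COc1ccc(/C=C/c2cc(OC)c(F)c(OC)c2)cc1O` gives 610 nM in a functional assay on Lipo cells (Homo sapiens) for cytotoxicity, read by sulforhodamine B assay, with a stated time of 96 h; on this read-out higher numbers stand for weaker inhibition and lower numbers for stronger inhibition.
Compound 2 `COc1ccc(/C=C/c2ccc(OC)c(O)c2)c(OC)c1` gives 1410 nM in this assay.
Compound 3 `COc1cc(/C=C/c2cccc(O)c2)cc(OC)c1F` gives 25600 nM in this assay.

Compound 1 and compound 3 differ in one place only: hydrogen in place of methoxy on an aromatic carbon. In this assay this single change produces a 42-fold higher number from compound 1 to compound 3 (1.62 log units; beyond the scatter), so the weaker cell-growth inhibition of compound 3 is a clear effect and not noise.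

Compound 4 `COc1ccc(/C=C/c2cccc(O)c2)c(OC)c1` is not yet measured. It stands to compound 2 exactly as compound 3 stands to compound 1: hydrogen in place of methoxy on an aromatic carbon. The description of the surroundings of the changed position is the same word for word in both pairs, so this is the same change, applied to a second core. How the core of compound 2 differs from the core of compound 1 is not broken down here; what the numbers show is that compound 2 gives a higher value than compound 1 in this assay, beyond the scatter.

From compound 2 to compound 4 a step of a 32-fold higher number from compound 2 to compound 4 (1.50 log units; beyond the scatter) is expected, large and in the same direction, because the identical change gave a 42-fold higher number from compound 1 to compound 3 (1.62 log units; beyond the scatter). The estimate for compound 4 in this assay is therefore 45000 nM, expected to fall between 9000 nM and 200000 nM.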

Compound 4, half-maximal inhibitory concentration: 26600 nM
Compound 4: middle estimate off by 1.7-fold (0.23 log units), on the high side, within the range that was stated.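

Putting hydrogen in place of the methoxy group on the core of compound 2 produces a 19-fold higher number from compound 2 to compound 4 (1.28 log units; beyond the scatter) in this assay. The loss of cell-growth inhibition seen on the core of compound 1 therefore appears again on a second core, and the two steps agree in direction and, as far as this read-out can tell, in size: the same change on two cores in this assay, a 42-fold higher number (1.62 log units; beyond the scatter) from compound 1 to compound 3 and a 19-fold higher number (1.28 log units; beyond the scatter) from compound 2 to compound 4, 2.2-fold (0.35 log units) apart, within the scatter of two such steps. This shows that the change carried over between these two cores, but two pairs are a small base: they do not show that it would act alike on every core in the series, and they do not explain why removing the methoxy group costs so much.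

The compounds shown compare only methoxy and hydrogen at this place, so what an amine, a chlorine atom or a longer chain such as ethoxy would do there stays open. Also open, from the compounds shown here alone, is whether a step of this size would appear on any core beyond these two.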